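This account rests on a few compounds, and the source may have more. Where it says the series, first, only, none or still open, it means among the compounds named here.

Compounds measured so far:
- compound 1, `CCc1cccc(NC(=O)CN2CCC(c3cccc[n+]3[O-])CC2)c1`: 62%
- compound 2, `O=C(NCN1CCC(c2cccc[n+]2[O-])CC1)c1cnccc1Cl`: 44%
- compound 3, `CC(C)Oc1cccc(NC(=O)CN2CCC(c3cccc[n+]3[O-])CC2)c1`: 48%

In a functional assay on HEK293 cells for agonist activity at D(4) dopamine receptor (Homo sapiens), read by FLIPR (a higher number here means a larger maximal response, a lower number a smaller maximal response), compound 2 gives the lowest of the three numbers. Against compound 3 it lies within the scatter; against compound 1 the gap is beyond the scatter, compound 1 reaching the larger maximal response.

The next compound, compound 4 `N#Cc1cccc(C(=O)NCN2CCC(c3cccc[n+]3[O-])CC2)c1`, differs from compound 2 in one place: 3-cyanophenyl in place of 4-chloropyridin-3-yl on a carbonyl carbon.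

Going by the values given here, only one measured step exists in the set, a number 14 percentage points lower from compound 1 to compound 3 (beyond the scatter), and it concerns the substituent on the anilide side of the shared core, not the aryl on the carbonyl carbon. Among the compounds with values here, no measured pair speaks to an exchange of the aryl bound to the carbonyl, so the step from compound 2 to compound 4 has no direct precedent here. The expected change is therefore none beyond the scatter, stated as a number 6 percentage points higher from compound 2 to compound 4 (within the scatter). For compound 4 the estimate in this assay is 50%, with a range from 30% to 70%.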

Compound 4, largest response reached (reported as efficacy), in percent of the reference or control that the assay uses: 69%
Beside the measured number, compound 4's estimate is 19 percentage points below it, and the stated range covers the measured number.
By their numbers in this assay, from the lowest: compounds 2 and 3 (each within the scatter of the next); then compounds 1 and 4 (each within the scatter of the next).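

The aryl on the carbonyl carbon now has a measured step of its own: in this assay, 3-cyanophenyl in place of 4-chloropyridin-3-yl gives a number 25 percentage points higher from compound 2 to compound 4 (beyond the scatter), so the maximal response in this series depends on this position as well as on the substituent of the anilide side. The exchange replaces a chlorine-bearing aromatic ring with 1 hetero atom by an aromatic ring of carbon only that carries a nitrile, so several features change in one step and this single pair cannot assign the rise to any one of them. Nothing available explains the size of this step.

On these data alone, whether the rise follows from gaining the nitrile or from losing the chlorine and the ring nitrogen stays open, and an unsubstituted phenyl on the same carbonyl carbon would separate the two. Also open, as far as these compounds go, is whether a carboxylic acid or a primary amide in place of the nitrile would hold the response.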